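Fluoro for Trifluoromethyl: Cytotoxicity Expected to Stay Tolerated

The compounds below may be only part of what the source reports. "The series", "measured", "known", "first", "only" and "open" are said of these compounds alone.

Compound 1, `N#CCCCn1c(Cn2c(=O)n(C3CC3)c3ccncc32)nc2nc(Cl)ccc21`, reaches only the assay limit, > 50000 nM.
Compound 2, `CS(=O)(=O)CCCn1c(Cn2c(=O)n(C3CC3)c3ccncc32)cc2cc(C(F)(F)F)ccc21`, reaches only the assay limit, > 50000 nM.
Compound 3, `N#CCCCn1c(Cn2c(=O)n(-c3ccncn3)c3ccncc32)cc2cc(Cl)ccc21`, reaches only the assay limit, > 50000 nM.

Of the compounds shown here, three have been tested in an ADME assay on HeLa cells (Homo sapiens) for cytotoxicity, read by ATP content, with a stated time of 3 days; a higher number here means that more compound is tolerated, a lower number that less compound is tolerated. For compound 2 the value is a limit rather than a number, and the same holds for the other two compounds, as the limit of > 50000 nM in this assay, at which 3 of the 3 values shown sit, shows. Within the data shown here, compound 2 therefore stands level with everything measured, and no step between measured compounds can be drawn. Compound 4, `CS(=O)(=O)CCCn1c(Cn2c(=O)n(C3CC3)c3ccncc32)cc2cc(F)ccc21`, differs from compound 2 by fluoro in place of trifluoromethyl on an aromatic carbon. With every measured compound at the limit, the estimated step that the limit leaves unreadable from compound 2 to compound 4 is not expected to go beyond the scatter in this assay. Compound 4 is expected to give 60000 nM, within 30000 nM to 150000 nM.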

Compound 4, half-maximal cytotoxic concentration: > 50000 nM
Compound 4: only a limit was reported; the forecaster's own chance of this, stated with the estimate: 85%; the middle value is on the limit's open side.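

Compound 2 and compound 4 both stop at the assay limit in this assay, so no step can be read between them: the limit of > 50000 nM in this assay, at which 4 of the 4 values shown sit.

The compounds shown leave open whether fluoro and trifluoromethyl differ at all once cells are exposed past that limit.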